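Ester replaces acid side chain on the shared core

This account rests on a few compounds, and the source may have more. Where it says the series, first, only, none or still open, it means among the compounds named here.

Compound 1 `CN1CCN(C(=O)/C=C/c2ccncc2-c2ccc3ccccc3c2)CC1` is the reference point of this set: in an assay on a protein complex for inhibition of CDK8/Cyclin C (Homo sapiens), with a stated time of 1 h (on this read-out lower numbers stand for stronger inhibition and higher numbers for weaker inhibition), compound 1 gives 43.6 nM. For the measured compounds named here, compound 2 `O=C(O)COc1ccncc1-c1ccc2ccccc2c1` keeps the same core but carries a carboxymethoxy group; in this assay compound 2 gives "not determined" (no result reported), so no number stands for it and no step from it can be measured. Compound 3 `CCOC(=O)/C=C/c1ccncc1-c1ccc2ccccc2c1` is the next member; it differs from compound 2 by 2-(ethoxycarbonyl)ethenyl in place of carboxymethoxy on an aromatic carbon, the place being an aromatic carbon of a six-membered aromatic ring with one nitrogen, ortho to a large group and opposite the ring nitrogen. Going by the values given here, with no result for compound 2, no size or direction of the step to compound 3 can be read from the data; the only anchor is the value of compound 1, which shares the ethenyl linker but ends in an amide rather than an ester. Compound 3 is expected to come in at about 200 nM, with a range of 40 nM to 1500 nM, resting on compound 1 at 43.6 nM.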

Compound 3, half-maximal inhibitory concentration: 53.3 nM
For compound 3 the middle estimate is 3.8-fold (0.57 log units) above the measured one, within the range that was stated.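

In this assay, ethoxy in place of 4-methylpiperazin-1-yl on the carbonyl carbon gives a 1.2-fold higher number from compound 1 to compound 3 (0.09 log units; within the scatter). The two end groups therefore cannot be told apart on this read-out: an ester carrying the 2-(ethoxycarbonyl)ethenyl group matches the amide of compound 1, so the 4-methylpiperazin-1-yl ring is not required for a value of this size on the shared core. What the pair adds is that, with the ethenyl linker kept, this end of the side chain accepts two quite different groups without a change beyond the scatter, whereas the step from compound 2 cannot be read, as no number stands for it. No measurement shown here explains why the two end groups match.

The compounds shown leave open whether a free carboxylic acid on the same ethenyl linker, or a primary amine-derived amide, would also stay within the scatter of compound 1 and compound 3. They also leave open how a saturated two-carbon linker or a longer chain in place of ethoxy would read in this assay.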